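Enlarging the sulfur side chain of compound 1

The source may hold more compounds than are shown below. What is called first, only, known or untested is meant among the compounds shown, and "the series" means these compounds.

compound 1 (`CCSc1nnc(-c2cc(OC)c(OC)c(OC)c2)n1-c1ccc(OC)cc1`) > 60000 nM (a limit, not a number)
compound 2 (`COc1ccc(CSc2nnc(-c3cc(OC)c(OC)c(OC)c3)n2-c2ccc(OC)cc2)cc1`) 41100 nM
compound 3 (`COc1ccc(-n2c(SCc3ccc(F)cc3)nnc2-c2cc(OC)c(OC)c(OC)c2)cc1`) 35000 nM

In a functional assay on HepG2 cells (Homo sapiens) for inhibition, read by MTT assay, with a stated time of 48 h (on this read-out lower numbers stand for stronger inhibition and higher numbers for weaker inhibition), compound 1 gives only a limit (> 60000 nM) and no number. Compound 1 therefore stands at the limit of > 60000 nM in this assay, at which 1 of the 3 values shown sits, and any step away from it can be told only as a floor.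

Compound 4 (`COc1ccc(-n2c(SCC(=O)c3ccc(OC)c(O)c3)nnc2-c2cc(OC)c(OC)c(OC)c2)cc1`) carries (3-hydroxy-4-methoxyphenyl)carbonyl in place of methyl on a saturated chain carbon bound to a sulfur. Two measured steps at that same place bear on this change, an at least 1.4-fold lower number from compound 1 to compound 2 (0.16 log units; that floor lies within the scatter) and also an at least 1.7-fold lower number from compound 1 to compound 3 (0.23 log units; that floor lies within the scatter) (both are floors). The two replacements themselves hardly separate, with a 1.2-fold lower number from compound 2 to compound 3 (0.07 log units; within the scatter) (no difference to read). Compound 4 is expected in this assay to give a lower number than compound 1, with compound 2 at 41100 nM and compound 3 at 35000 nM as the nearest guides. For the measured compounds named here, no measured compound carries the entering group, so the expected size is loose and the range wide. The expected step is an at least 3.0-fold lower number from compound 1 to compound 4 (0.47 log units; beyond the scatter) (an estimate). For compound 4 the estimated value is 20000 nM with an expected range from 3000 nM to 60000 nM (not yet measured).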

Compound 4, half-maximal inhibitory concentration: > 60000 nM
Compound 4 ended at the assay's limit (the forecaster's own chance of this, stated with the estimate: 15%); middle value at least 3.0-fold (0.47 log units) from the limit.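

Compound 4 shows that enlarging the sulfur side chain does not always bring a readable value: in this assay compound 4 gives > 60000 nM, which is a limit of the assay and not a number. Set against the two larger groups already measured at this place, (3-hydroxy-4-methoxyphenyl)carbonyl gives an at least 1.7-fold higher number from compound 3 to compound 4 (0.23 log units; that floor lies within the scatter) and an at least 1.4-fold higher number from compound 2 to compound 4 (0.16 log units; that floor lies within the scatter); both floors lie within the scatter, so they point the same way but do not establish that this group is worse than 4-fluorophenyl or 4-methoxyphenyl. The step between the small methyl end of the series and this largest group cannot be read, since both of its ends are limits: the limit of > 60000 nM in this assay, at which 2 of the 4 values shown sit.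

The compounds shown leave open whether the carbonyl or the 3-hydroxy-4-methoxyphenyl ring keeps compound 4 at the limit, and how far above the limit compound 1 and compound 4 really lie. They also do not tell how an amine or a carboxylic acid on the saturated chain carbon bound to a sulfur would read.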